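The compounds below may be only part of what the source reports. "The series", "measured", "known", "first", "only" and "open" are said of these compounds alone.

Of the compounds shown here, three have so far been tested in a physicochemical assay for solubility, read by nephelometry, measured as kinetic solubility, at pH 2.0; a lower number here means a less soluble compound, a higher number a more soluble compound. Compound 1 `NCc1csc(NC(=O)c2ccccn2)n1` gives > 100 ug/mL, which is a limit of the assay and not a number. Compound 2 `NCc1csc(NC(=O)c2ncccn2)n1` gives > 100 ug/mL, again a limit. Compound 3 `CC(C)(C)c1cc(C(=O)Nc2cccc(CN)c2)n(Cc2ccccc2)n1` gives > 100 ug/mL, also a limit. Compound 3 therefore has no exact value and shares its standing with the other two: the limit of > 100 ug/mL in this assay, at which 3 of the 3 values shown sit.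

Compound 4 `Cc1csc(NC(=O)c2cc(C(C)(C)C)nn2Cc2ccccc2)n1` differs from compound 3 at one place, with 4-methyl-1,3-thiazol-2-yl in place of 3-(aminomethyl)phenyl on an amide-type nitrogen. The expectation starts from compound 3, which carries an aminomethyl group and stands at > 100 ug/mL, a limit. Going by the values given here, compound 4 has no aminomethyl group, unlike all three measured compounds, and no measured pair shows what losing it does. A fall beyond the usual scatter in this assay is expected, but its size is only a judgement, estimated as an at least 3.3-fold lower number from compound 3 to compound 4 (0.52 log units; beyond the scatter). For compound 4 the estimated solubility is 30 ug/mL, with an expected range of 8 ug/mL to 100 ug/mL.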

Compound 4, solubility: < 1.6 ug/mL
Compound 4: only a limit was reported; the forecaster's own chance of this, stated with the estimate: 25%; middle value at least 18-fold (1.27 log units) away from the limit.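

In this assay the change on the amide-type nitrogen gives an at least 62-fold lower number from compound 3 to compound 4 (1.79 log units; beyond the scatter). The earlier compounds shown here all sat at one limit and could not show that this place can move the read-out so far. Compound 4 gives < 1.6 ug/mL, which is a limit of the assay and not a number, and it now stands alone at the low end of the values shown: the limit of < 1.6 ug/mL in this assay, at which 1 of the 4 values shown sits.

The step swaps the whole 3-(aminomethyl)phenyl group for 4-methyl-1,3-thiazol-2-yl, so the loss of the aminomethyl group and the change of ring cannot be told apart here. On these data alone, a plain phenyl group at this place, or a primary amine carried on the thiazole ring of compound 4, would separate the two, and the exact size of the drop stays open since both ends of the step are limits.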